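Trimming cyclopentyl down to isopropyl

This account rests on a few compounds, and the source may have more. Where it says the series, first, only, none or still open, it means among the compounds named here.

Three measured compounds share one core and differ only in the group on an oxygen on an aromatic ring. In a functional assay on CAL-51 cells (Homo sapiens) for antiproliferative activity, read by luminescence and CellTiter-Glo, with a stated time of 3 days (a lower number here means a stronger inhibitor, a higher number a weaker inhibitor), compound 1 `COc1cc(C(=O)N(C)C)ccc1Nc1nc(OC2CCCCC2)c2cc[nH]c2n1`, carrying cyclohexyl, gives 190 nM, and compound 2 `COc1cc(C(=O)N(C)C)ccc1Nc1nc(O[C@H]2CCOC(C)(C)C2)c2cc[nH]c2n1`, carrying 2,2-dimethyloxan-4-yl, gives 131 nM. These two cannot be told apart, since a 1.5-fold lower number from compound 1 to compound 2 (0.16 log units; within the scatter) is a step within the scatter. Compound 3 `COc1cc(C(=O)N(C)C)ccc1Nc1nc(OC2CCCC2)c2cc[nH]c2n1`, carrying cyclopentyl, gives 497 nM, the highest number of the three and so the weakest inhibitor here.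

Compound 4 `COc1cc(C(=O)N(C)C)ccc1Nc1nc(OC(C)C)c2cc[nH]c2n1` has isopropyl in place of cyclopentyl on an oxygen on an aromatic ring. The closest guide is the change from cyclohexyl to cyclopentyl, where the carbon-only group gets smaller, and this gives a 2.6-fold higher number from compound 1 to compound 3 (0.42 log units; beyond the scatter). The change from 2,2-dimethyloxan-4-yl to cyclopentyl, a 3.8-fold higher number from compound 2 to compound 3 (0.58 log units; beyond the scatter), points the same way but says less, as its starting group is of a different kind. For the measured compounds named here, no measured compound has a group without a ring, so this reasoning rests on little. A modest move towards weaker inhibition is expected, with the estimated step being a 2.0-fold higher number from compound 3 to compound 4 (0.30 log units; within the scatter). The estimate for compound 4 is 1000 nM, with an expected range from 400 nM to 2500 nM.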

Compound 4, half-maximal inhibitory concentration: 1270 nM
Beside the measured number, compound 4's estimate is 1.3-fold (0.10 log units) below it, within the range that was stated.
By their numbers in this assay, from the lowest: compounds 2 and 1 (each within the scatter of the next); then compound 3; then compound 4.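

In this assay, the move from cyclopentyl to isopropyl, which drops from 5 heavy atoms to 3 and removes the ring, gives a 2.6-fold higher number from compound 3 to compound 4 (0.41 log units; beyond the scatter), so the carbon-only groups in compounds 1, 3 and 4 now form a series of three in which the number rises at each step as the group gets smaller. The full cost of this shrinkage shows against the two largest groups, with a 6.7-fold higher number from compound 1 to compound 4 (0.83 log units; beyond the scatter) and a 9.7-fold higher number from compound 2 to compound 4 (0.99 log units; beyond the scatter), which makes compound 4 the weakest inhibitor of the four, as all its steps lie beyond the scatter. Nothing measured here explains why this position responds in this way.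

Isopropyl differs from cyclopentyl both in its number of carbon atoms and in having no ring, so these compounds cannot show which of the two matters more. Cyclobutyl or an open chain such as pentyl on the same oxygen would help to separate them, and an amine on a ring of this kind would test a very different sort of group.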